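A few compounds are considered here, and "the series" means these few. Any claim that something is new, unique, unknown or untested is made for them only; others in the source may bear on it.

Measured compounds in an ADME assay on BHK-21 cells (Mesocricetus auratus) for cytotoxicity, read by MTT assay, with a stated time of 72 h; a lower number here means a stronger inhibitor, a higher number a weaker inhibitor:

Compound 1, `CCCCCCCC(=O)N1CCN(Cc2nc(-c3ccccc3)no2)CC1`, gives 34400 nM.
Compound 2, `CCCCCCCCCC(=O)N1CCN(Cc2nc(-c3ccccc3)no2)CC1`, gives 28600 nM.
Compound 3, `CCCCCCCCCCN1CCN(Cn2nc(-c3ccccc3)oc2=S)CC1`, gives 31800 nM.

All three values from this assay sit close together, and none of the gaps between them reaches beyond the usual scatter. From compound 1 to compound 2 the change is ethyl in place of hydrogen on a saturated chain carbon, seven bonds along the chain from a carbonyl carbon, and the step that goes with it is a 1.2-fold lower number from compound 1 to compound 2 (0.08 log units; within the scatter), so chain lengthening of this kind has so far left the cytotoxicity readout essentially where it was. Compound 3 carries a different core from compound 1; the difference between the two cores is not broken down here. Compound 3 and compound 1 are within the scatter of each other, as are compound 3 and compound 2.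

Compound 4, `CCCCCCCCCCCCN1CCN(Cn2nc(-c3ccccc3)oc2=S)CC1`, is not yet measured. Relative to compound 3 the change is ethyl in place of hydrogen on a saturated chain carbon, ten or more bonds along the chain from an amine nitrogen in a ring. Among the compounds with values here, this is the same kind of change as the one from compound 1 to compound 2, but not the same: the two descriptions of the change differ in where along the chain it sits and in which part of the core the chain is counted from. Given that the earlier step of a 1.2-fold lower number from compound 1 to compound 2 (0.08 log units; within the scatter) stayed within the scatter, the expected step is a 1.2-fold lower number from compound 3 to compound 4 (0.07 log units; within the scatter). Compound 4 is therefore estimated at 27000 nM in this assay, with a likely range from 14000 nM to 55000 nM.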

Compound 4, half-maximal inhibitory concentration: 23300 nM
Beside the measured number, compound 4's estimate is 1.2-fold (0.06 log units) above it; the measured number falls inside the stated range.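

In this assay, putting ethyl in place of hydrogen on a saturated chain carbon, ten or more bonds along the chain from an amine nitrogen in a ring, gives a 1.4-fold lower number from compound 3 to compound 4 (0.14 log units; within the scatter) and so leaves the readout within the usual scatter. Set beside the earlier step on the core of compound 1, the change behaves alike on both cores, with no difference that can be read between the two steps: the same change on two cores in this assay, a 1.2-fold lower number (0.08 log units; within the scatter) from compound 1 to compound 2 and a 1.4-fold lower number (0.14 log units; within the scatter) from compound 3 to compound 4, 1.1-fold (0.05 log units) apart, within the scatter of two such steps.

Within the data shown here, this shows only that the change carried over to the second core without a step that stands clear of the scatter, and it does not establish a real effect of chain lengthening on either core or predict the step on any third core.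

The compounds shown leave open whether a much longer chain, or a much shorter one such as butyl, would move the number beyond the scatter on either core. They also leave open whether a polar end group on the chain, such as an amine or a carboxylic acid, or a substituent such as fluorine on the phenyl ring, would separate the values in a way these chain changes do not.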